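A few compounds are considered here, and "the series" means these few. Any claim that something is new, unique, unknown or untested is made for them only; others in the source may bear on it.

Working notes on the series, read in an ADME assay on Caco-2 cells (Homo sapiens) for permeability, read by LC-MS, in the apical to basolateral direction, with a stated time of 60 min, at pH 6.5; a higher number here means that the compound crosses the layer faster, a lower number that the compound crosses the layer more slowly. Going by the values given here, compound 1 `O=C(NCc1cc(Cl)ccc1-n1cnnn1)[C@@H]1C[C@@H]2C[C@@H]2N1C(=O)[C@H](O)CC1CC1` gives 3.6 10^-6 cm/s, and compound 2 `O=C(NCc1cc(Cl)ccc1-n1cnnn1)[C@@H]1C[C@@H]2C[C@@H]2N1C(=O)[C@H](O)c1ccccc1` gives 8 10^-6 cm/s, the higher of the two numbers so far. Compound 3 `COC(C)(C)[C@@H](O)C(=O)N1[C@H](C(=O)NCc2cc(Cl)ccc2-n2cnnn2)C[C@@H]2C[C@@H]21` is not yet measured. It differs from compound 2 as follows: 1-methoxy-1-methylethyl in place of phenyl on a saturated chain carbon bound to a carbonyl carbon and an oxygen on a saturated carbon. In words, 1-methoxy-1-methylethyl stands in place of phenyl on a saturated chain carbon bound to a carbonyl carbon and an oxygen on a saturated carbon. Among the compounds with values here, only one measured step bears on this change, and it lies at the same place: a 2.2-fold higher number from compound 1 to compound 2 (0.35 log units; beyond the scatter), a modest step, with phenyl entering. Within the data shown here, compound 3 loses that phenyl, and the data hold no example of its new group, so a modest fall of similar size is expected. The expected step is a 2.0-fold lower number from compound 2 to compound 3 (0.30 log units; within the scatter). For compound 3 the estimated value is 4 10^-6 cm/s, with an expected range of 1.8 10^-6 cm/s to 8.5 10^-6 cm/s.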

Compound 3, apparent permeability: 16 10^-6 cm/s
Compound 3: middle estimate off by 4.0-fold (0.60 log units), on the low side; measured number outside the range, above it.
By their numbers in this assay, from the lowest: compound 1; then compounds 2 and 3 (each within the scatter of the next).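

At this position, a ring is not needed to hold the number in this assay: 1-methoxy-1-methylethyl, which has no ring and carries one hydrogen-bond acceptor, replaces phenyl with a 2.0-fold higher number from compound 2 to compound 3 (0.30 log units; within the scatter) and leaves compound 2 and compound 3 level. Against the cyclopropylmethyl group, the new group gives a 4.4-fold higher number from compound 1 to compound 3 (0.65 log units; beyond the scatter), so both phenyl and 1-methoxy-1-methylethyl now stand above cyclopropylmethyl in this series. No measurement on hand explains why these groups read as they do.

The compounds shown leave open whether the methoxy oxygen or the branched carbon carries the difference from compound 1, a question that a tert-butyl group at this place would address. From the compounds shown here alone, how an amine or a carboxylic acid at the same place would read in this assay also remains open.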